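Swapping a Chain End for a Ring in a Lipophilicity Series

This account rests on a few compounds, and the source may have more. Where it says the series, first, only, none or still open, it means among the compounds named here.

Compound 1, `CCCCCCc1nc2ccccc2[nH]1`: 3.93
Compound 2, `CCCCCCCCCCCCCc1nc2ccccc2[nH]1`: 7.43

Both measured compounds share one core and differ only in the saturated chain attached to it. In a physicochemical assay for lipophilicity (on this read-out higher numbers stand for higher lipophilicity and lower numbers for lower lipophilicity), compound 1 gives 3.93, the lower of the two numbers, and compound 2 gives 7.43. For the measured compounds named here, the single step measured so far, a number 3.50 log units higher from compound 1 to compound 2 (beyond the scatter), shows how strongly a longer chain raises this read-out.

Compound 3, `c1ccc(CCCc2nc3ccccc3[nH]2)cc1`, has not yet been measured. It differs from compound 1 by phenyl in place of propyl on a saturated chain carbon, three bonds along the chain from an aromatic carbon. The step from compound 1 to compound 2 bears on this only loosely, since there the chain grew while here propyl gives way to phenyl. Going by the values given here, no measured step of this kind exists, so the expectation leans on the chain effect seen in a number 3.50 log units higher from compound 1 to compound 2 (beyond the scatter) and is a much smaller rise, a number 0.37 log units higher from compound 1 to compound 3 (beyond the scatter). Compound 3 is estimated at 4.3, within a range from 3.8 to 4.8.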

Compound 3, partition coefficient: 4.46
Beside the measured number, compound 3's estimate is 0.16 log units below it; the range from low to high includes it.
By their numbers in this assay, from the lowest: compound 1; then compound 3; then compound 2.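

At this place, three bonds along the chain from an aromatic carbon, a ring can replace the chain end and this assay still moves upward, with a number 0.53 log units higher from compound 1 to compound 3 (beyond the scatter) as the result. The earlier step showed only a chain growing, at a different place, with a number 3.50 log units higher from compound 1 to compound 2 (beyond the scatter) when heptyl entered; here the entering group is a ring, and phenyl brings 6 heavy atoms where propyl had 3. Nothing measured here gives a reason for the size of this rise.

Still open, from the compounds shown here alone, is whether a saturated ring such as cyclohexyl would give a similar step to phenyl at this place. Equally open, going by these compounds, is how the number would respond to a phenyl ring carrying an amine or a carboxylic acid.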